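Pyridinyl for Phenyl on the Benzyl Ether of Compound 1

This account rests on a few compounds, and the source may have more. Where it says the series, first, only, none or still open, it means among the compounds named here.

compound 1 `O=C(COCc1ccccc1)N1CCN(c2cc(Cl)ccn2)CC1` — 570 nM
compound 2 `O=C(COCc1ccccc1)N1CCN(c2ccncc2)CC1` — a limit, > 25000 nM

Among the compounds with values here, in a functional assay on HEK293 cells for positive allosteric modulation of metabotropic glutamate receptor 5 (Homo sapiens), read by FLIPR and calcium flux (a lower number here means that less compound is needed, a higher number that more compound is needed for the effect), compound 1 gives 570 nM, the only number among the two values shown. For compound 2 this assay reports only a limit, > 25000 nM (the limit of > 25000 nM in this assay, at which 1 of the 2 values shown sits). Within the data shown here, the one measured step, an at least 43-fold higher number from compound 1 to compound 2 (1.64 log units; beyond the scatter), concerns the group on the amine nitrogen in a ring and is large.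

Compound 3 `O=C(COCc1ccncc1)N1CCN(c2cc(Cl)ccn2)CC1` keeps that 4-chloropyridin-2-yl group intact and differs from compound 1 only at the ether end: pyridin-4-yl in place of phenyl on a saturated chain carbon bound to an oxygen on a saturated carbon. Among the measured compounds shown here, no measured step touches this place, so the step from compound 1 to compound 2 cannot be carried over to it, and the expectation rests on the structural change alone. Compound 3 is expected to show a modest rise in this assay, a 2.6-fold higher number from compound 1 to compound 3 (0.42 log units; beyond the scatter), a step that may or may not exceed the usual scatter. Compound 3 is estimated at 1500 nM, with a range from 400 nM to 6000 nM.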

Compound 3, half-maximal effective concentration: 4200 nM
Estimate against measurement, compound 3: 2.8-fold (0.45 log units) below; the measured number falls inside the stated range.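

The ether end proves to be a place that responds in this assay: pyridin-4-yl in place of phenyl on a saturated chain carbon bound to an oxygen on a saturated carbon gives a 7.4-fold higher number from compound 1 to compound 3 (0.87 log units; beyond the scatter) and so counts as a modest step that lies beyond the scatter. The two rings have the same number of heavy atoms and differ by one nitrogen and one hydrogen-bond acceptor, so a small difference in composition at this place is enough to raise the number, yet compound 3 still gives a measured value of 4200 nM and not a limit. Nothing measured in this set accounts for why the number rises at this place.

From the compounds shown here alone, it remains open whether the step depends on where the ring nitrogen sits, as pyridin-3-yl or pyridin-2-yl on the same carbon would show, or whether a pyrimidine ring would move the number further. Also open, going by these compounds, is whether a longer chain between the ether oxygen and the ring, or a chloro group on the phenyl ring of compound 1, would be taken up at this place in the same way.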